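The source may report more compounds than this note shows. Statements on the series, on what has been measured and on what is new or still open speak of the compounds shown alone.

- compound 1 (`N=C(N)N/N=C/c1c(-c2ccsc2)nc2sccn12`) gives 31600 nM
- compound 2 (`N=C(N)N/N=C/c1c(-c2cccs2)nc2sccn12`) gives 26900 nM

Among the measured compounds shown here, in a functional assay on cells (Cancer cell lines, Homo sapiens) for inhibition (on this read-out higher numbers stand for weaker inhibition of growth and lower numbers for stronger inhibition of growth), compound 2 stands level with compound 1, since the only measured step (a 1.2-fold lower number from compound 1 to compound 2 (0.07 log units; within the scatter)) stays within the scatter. Compound 3 (`Cc1cc(-c2nc3sccn3c2/C=N/NC(=N)N)c(C)s1`) differs from compound 2 by 2,5-dimethylthiophen-3-yl in place of thiophen-2-yl on an aromatic carbon on the shared core. For the measured compounds named here, the thiophene attachment has been varied only in that one measured step, and no measured step tests the methyl groups, so the estimate stays wide. No step beyond the scatter is expected in this assay and no direction is favoured, the estimated change being small (a 1.2-fold lower number from compound 2 to compound 3 (0.09 log units; within the scatter)). Compound 3 is expected at 22000 nM with an estimated range from 8000 nM to 60000 nM around it.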

Compound 3, concentration for total growth inhibition: 33900 nM
Compound 3: the middle estimate sits 1.5-fold (0.19 log units) below what was measured; the measured number falls inside the stated range.
By their numbers in this assay, from the lowest: compounds 2, 1 and 3 (each within the scatter of the next).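

In this assay the two methyl groups of 2,5-dimethylthiophen-3-yl bring no step beyond the scatter, whether read as a 1.3-fold higher number from compound 2 to compound 3 (0.10 log units; within the scatter) or as a 1.1-fold higher number from compound 1 to compound 3 (0.03 log units; within the scatter). This position, on an aromatic carbon next to the ring nitrogen, therefore carries the larger group of 7 heavy atoms with its number still level with those of compound 1 and compound 2. No evidence is at hand to explain this flat result. Going by these compounds, all three compounds carry a thiophene here, so it stays open whether an amine, a carboxylic acid or a longer alkyl chain in its place would move the number beyond the scatter.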